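Gem-dimethyl variant of a thiazine enone in aortic tissue

The source may report more compounds than this note shows. Statements on the series, on what has been measured and on what is new or still open speak of the compounds shown alone.

Compound 2, `CC1CN(C2=CCCC2=O)c2cc(C(F)(F)F)ccc2S1`, was examined in a functional assay on aorta (Rattus norvegicus, strain Wistar), in the presence of a further agent that is not named here (on this read-out lower numbers stand for smaller maximal responses and higher numbers for larger maximal responses), and in this test compound 2 gives 63%. Within the data shown here, that is the only number available for this series: compound 1, `CC1(C)CN(C2=CCCC2=O)c2cc(N)ccc2S1`, was run in the same setting, yet for compound 1 the result is given as "not determined" (no result reported), so nothing can be said of how the amino and trifluoromethyl analogues compare.

Compound 3, `CC1(C)CN(C2=CCCC2=O)c2cc(C(F)(F)F)ccc2S1`, differs from compound 2 in one place, (methyl in place of hydrogen on a saturated ring carbon). Among the measured compounds shown here, no pair of measured compounds shows what adding a methyl to this saturated ring carbon does to the maximal response, so there is no step to lean on. With only one data point and a modest change, the expectation for this assay is a step of a number 3 percentage points lower from compound 2 to compound 3 (within the scatter), which is no change beyond the usual scatter. Compound 3 is therefore estimated to reach 60%, within a range from 40% to 80%.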

Compound 3, largest response reached (Emax), in percent of the reference or control that the assay uses: 96%
For compound 3 the middle estimate is 36 percentage points below the measured one, and the stated range ends below it.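

In this assay, methyl in place of hydrogen on the saturated ring carbon next to the ring sulfur gives a number 33 percentage points higher from compound 2 to compound 3 (beyond the scatter). This shows that the position is not indifferent to substitution: a change of a single carbon atom, with no hydrogen-bond donor or acceptor added, is enough to alter the maximal response in this test. Nothing available here explains why this step is so large.

Going by these compounds, whether an ethyl group at this carbon would raise the maximal response further or lower it remains open, as does the effect of a hydroxyl group there. On these data alone, for compound 1 the entry reads "not determined" (no result reported), so it also stays unknown how the amino group compares with the trifluoromethyl group of compound 3.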